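This account rests on a few compounds, and the source may have more. Where it says the series, first, only, none or still open, it means among the compounds named here.

Working notes on the series around the shared core.

Compound 1, `O=C(CCc1ccc(F)cc1)c1[nH]c2ccccc2c1-c1ccc(F)cc1`, is the reference point of the set. In an assay on cell membranes for displacement of a labelled ligand from metabotropic glutamate receptor 5 (Rattus norvegicus), tested at 1 uM (on this read-out lower numbers stand for less inhibition and higher numbers for more inhibition at the one concentration tested (going by the name of the read-out)), compound 1 gives 4%. Compound 2, `O=C(CCc1ccccc1)c1sccc1-c1ccccc1`, carries the same ketone linker to a different core. In this assay compound 2 gives 0%, the lowest of the two numbers recorded so far; the nearest number, that of compound 1, lies within the usual scatter of repeated measurements, so the two readings cannot be ordered against each other. On what has been measured, neither compound shows inhibition that stands out from the noise of the assay.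

The next compound to be measured is compound 3, `O=C(CCc1ccccc1)c1sccc1-c1ccc(F)cc1`. It differs from compound 2 in one place: fluoro in place of hydrogen on an aromatic carbon. Among the compounds with values here, no pair of measured compounds yet differs by a single change, so there is no measured step to lean on, and the two numbers that exist give no hint of a trend tied to fluoro on the ring.

The expected step from compound 2 to compound 3 in this assay is a number 2 percentage points higher from compound 2 to compound 3 (within the scatter), that is, no change beyond the scatter in either direction. Compound 3 is therefore estimated at 2% in this assay, with a range of -8% to 12%.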

Compound 3, a percentage reported as inhibition, at one concentration (the size of the read-out at that concentration, not a potency): 0%
The estimate for compound 3 lay 2 percentage points above the measured number; the measured number falls inside the stated range.
By their numbers in this assay, from the lowest: compounds 2, 3 and 1 (each within the scatter of the next).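

In this assay, within the data shown here, the swap of fluoro for hydrogen on an aromatic carbon of the six-membered ring, para to a large group, gives no change at the digits printed from compound 2 to compound 3 (within the scatter) and so supplies the first measured single change. At this position, and on this one pair alone, going from phenyl to 4-fluorophenyl does not produce a reading that can be told apart from the parent, and neither compound of the pair shows inhibition that stands out from the noise. No measurement to hand bears on why the reading stays where it does.

As far as these compounds go, whether a different group at the same ring carbon, such as an amine or a carboxylic acid, or a longer chain in place of the linker, would give a number beyond the scatter remains open. From the compounds shown here alone, with both readings of this pair at the bottom of the read-out, it also remains open whether fluoro at this position would matter on a compound that shows clear inhibition.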